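Methoxy to hydrogen on two cores: working notes

The source may report more compounds than this note shows. Statements on the series, on what has been measured and on what is new or still open speak of the compounds shown alone.

Measured so far in a functional assay on WM 266-4 cells (Homo sapiens) for inhibition, read by MTT assay, with a stated time of 24 h; on this read-out lower numbers stand for stronger inhibition of growth and higher numbers for weaker inhibition of growth:
compound 1 `COc1ccc(C2=NN(C(=O)C3COc4ccccc4O3)C(c3cccc(F)c3)C2)cc1` gives 6720 nM
compound 2 `O=C(C1COc2ccccc2O1)N1N=C(c2ccccc2)CC1c1cccc(F)c1` gives 1450 nM
compound 3 `COc1ccc(C2CC(c3ccccc3)=NN2C(=O)c2ccc3c(c2)OCCO3)cc1` gives 8370 nM

Compound 1 and compound 2 share one core and differ only in the change (hydrogen in place of methoxy on an aromatic carbon). That change produced a 4.6-fold lower number from compound 1 to compound 2 (0.67 log units; beyond the scatter), a step beyond the usual scatter of this assay.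

Compound 3 sits on a different core. Its value and that of compound 1 lie within the scatter of each other, so no order between them is claimed. Against compound 2, compound 3 gives the higher number, and that gap is beyond the scatter. The difference between the core of compound 1 and the core of compound 3 is not broken down here.

Compound 4 `O=C(c1ccc2c(c1)OCCO2)N1N=C(c2ccccc2)CC1c1ccccc1` has not yet been measured in this assay. It differs from compound 3 by hydrogen in place of methoxy on an aromatic carbon. The place of the change is described in the same words as for the step from compound 1 to compound 2, so this is taken as the same change, made a second time, on a second core.

Compound 4 is expected to show a 4.2-fold lower number from compound 3 to compound 4 (0.62 log units; beyond the scatter). This expectation rests on the step of a 4.6-fold lower number from compound 1 to compound 2 (0.67 log units; beyond the scatter), which this change gave once already, with some allowance for the core being different. Compound 4 is therefore estimated at 2000 nM, with a likely range from 900 nM to 4500 nM.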

Compound 4, concentration for 50% growth inhibition: 1370 nM
For compound 4 the middle estimate is 1.5-fold (0.16 log units) above the measured one; the range from low to high includes it.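

In this assay, hydrogen in place of methoxy on an aromatic carbon, para to a large group, gave a 6.1-fold lower number from compound 3 to compound 4 (0.79 log units; beyond the scatter), and the size of this step cannot be told apart from that of the earlier one: the same change on two cores in this assay, a 4.6-fold lower number (0.67 log units; beyond the scatter) from compound 1 to compound 2 and a 6.1-fold lower number (0.79 log units; beyond the scatter) from compound 3 to compound 4, 1.3-fold (0.12 log units) apart, within the scatter of two such steps. Within these two pairs, the change carried from one core to the other, with the number falling in both and no pair going against it, so a step measured on one of these cores was a fair guide to the other. This does not show that the step would hold on any further core, since two pairs are a small basis, and it gives no reason for the step, which this growth read-out cannot supply on its own.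

The compounds shown leave open whether other groups at that place, such as a hydroxyl, an amine or a carboxylic acid, would give a number like that of hydrogen or like that of methoxy. Also open, as far as these compounds go, is how much each part of the difference between the core of compound 1 and the core of compound 3 contributes, as those two compounds differ in more than one place.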